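A Second Methyl Added on the Same Aromatic Carbon

A few compounds are considered here, and "the series" means these few. Any claim that something is new, unique, unknown or untested is made for them only; others in the source may bear on it.

Measured compounds:
Compound 1, `COc1cc2c(Oc3ccc(NC(=O)c4cn(-c5ccccc5C)nn4)cc3F)ccnc2cc1OCCCN1CCCCC1`: 3250 nM
Compound 2, `COc1cc2c(Oc3ccc(NC(=O)c4cn(-c5c(C)cccc5C)nn4)cc3F)ccnc2cc1OCCCN1CCCCC1`: 2140 nM

In a functional assay on MKN-45 cells (Homo sapiens) for cytotoxicity, read by MTT assay, with a stated time of 72 h (on this read-out lower numbers stand for stronger inhibition and higher numbers for weaker inhibition), compound 1 gives 3250 nM, and compound 2 gives 2140 nM. The two differ only by methyl in place of hydrogen on an aromatic carbon, and the step of a 1.5-fold lower number from compound 1 to compound 2 (0.18 log units; within the scatter).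

Compound 3 `COc1cc2c(Oc3ccc(NC(=O)c4cn(-c5ccccc5C)nn4)cc3F)ccnc2cc1OCCCN1CCC(C)CC1` differs from compound 1 by methyl in place of hydrogen on a saturated ring carbon; in this assay compound 3 is recorded as "not determined" (no result reported), so no single number stands for it. Compound 4 `COc1cc2c(Oc3ccc(NC(=O)c4cn(-c5c(C)cccc5C)nn4)cc3F)ccnc2cc1OCCCN1CCC(C)CC1` differs from compound 3 by methyl in place of hydrogen on an aromatic carbon, the same change as from compound 1 to compound 2, made on the core of compound 3 rather than on the core of compound 1.

Going by the values given here, the only observation of this change is the step from compound 1 to compound 2, which stays within the scatter, so a step of similar size is expected from compound 3 to compound 4 in this assay. Since compound 3 itself carries no number, the expectation for compound 4 rests on compound 2, whose value of 2140 nM serves as the nearest anchor. Compound 4 is therefore estimated at 2200 nM, with a range from 800 nM to 6500 nM.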

Compound 4, half-maximal inhibitory concentration: 4310 nM
The estimate for compound 4 lay 2.0-fold (0.29 log units) below the measured number; low and high end bracket the measured number.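

Going by these compounds alone, the one new step that can be read in this assay is a 2.0-fold higher number from compound 2 to compound 4 (0.30 log units; within the scatter), and it belongs to methyl in place of hydrogen on a saturated ring carbon, not to the aromatic methyl. The step from compound 3 to compound 4 cannot be read, as compound 3 carries no number, so the change from 2-methylphenyl to 2,6-dimethylphenyl has a measured size on the core of compound 1 alone, and the data neither confirm nor refute that it carries over to the core of compound 3. The data shown offer nothing that bears on the cause of any of these numbers.

The compounds shown leave open whether an ethyl group or a methoxy group, entering in place of the added methyl, would give a step beyond the scatter. They also leave open whether an amine or a carboxylic acid on that same aromatic ring would do so on either core.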